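The source may hold more compounds than are shown below. What is called first, only, known or untested is meant among the compounds shown, and "the series" means these compounds.

Measured so far in a physicochemical assay for solubility, at pH 7; a lower number here means a less soluble compound, a higher number a more soluble compound:
- compound 1 `CCc1ccc(Cl)cc1-n1cc(-c2cc(N)ncn2)cc1C(N)=O`: 128000 nM
- compound 2 `Cc1ccc(Cl)cc1-c1cn(-c2ncnc3[nH]ccc23)cc1C(N)=O`: 2000 nM

Compound 1 stands highest of these two compounds, and compound 2 lies below it by more than the usual scatter of repeat measurements. The next compound to be tested is compound 3 `CCc1ccc(Cl)cc1-n1cc(-c2cc(NC)ncn2)cc1C(N)=O`. It differs from compound 1 in one place: methyl in place of hydrogen on a nitrogen on an aromatic ring. A methyl replaces a hydrogen on a nitrogen on an aromatic ring, turning amino into methylamino. For the measured compounds named here, no pair of measured compounds shows this kind of change, so any expectation is cautious. A small downward step in this assay is expected, possibly no larger than the scatter. The expected change is a 1.6-fold lower number from compound 1 to compound 3 (0.20 log units; within the scatter). For compound 3 the estimated value is 80000 nM, with an expected range from 25000 nM to 200000 nM.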

Compound 3, solubility: 111000 nM
Compound 3: middle estimate off by 1.4-fold (0.14 log units), on the low side; measured number inside the range.
By their numbers in this assay, from the lowest: compound 2; then compounds 3 and 1 (each within the scatter of the next).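

In this assay, the step from amino to methylamino on the 6-aminopyrimidin-4-yl group gives a 1.2-fold lower number from compound 1 to compound 3 (0.06 log units; within the scatter), so the two compounds cannot be told apart in this measurement. For the compounds shown here, this is the first direct reading at this nitrogen: a single methyl in place of a hydrogen there leaves no change that can be separated from ordinary repeat variation. The data offer no explanation for this outcome, and none should be inferred from a single pair.

As far as these compounds go, one small methyl says little about what larger changes at this nitrogen would do, so an ethyl, a longer chain such as propyl, a second methyl giving dimethylamino, or an acetyl remains open. From the compounds shown here alone, it also remains open whether the same methyl would behave alike on a different core.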